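A few compounds are considered here, and "the series" means these few. Any claim that something is new, unique, unknown or untested is made for them only; others in the source may bear on it.

Measured so far:
compound 1 `C=C1CC[C@@H]2[C@](C)(COC(C)=O)[C@H](OC(C)=O)CC[C@@]2(C)[C@H]1CC(Nc1ccc(S(=O)(=O)Nc2nccc(C)n2)cc1)C1=CCOC1=O`: "not determined" (no result reported)
compound 2 `C=C1CC[C@@H]2[C@](C)(COC(C)=O)[C@H](OC(C)=O)CC[C@@]2(C)[C@H]1CC(Nc1ccc(S(=O)(=O)Nc2ccc(Cl)nn2)cc1)C1=CCOC1=O`: 3900 nM

Compound 1 and compound 2 share the same core and differ only in the group carried on the sulfonamide nitrogen. Among the compounds with values here, since compound 1 has no reported number, compound 2 stands alone: in a functional assay on Malme-3M cells (Homo sapiens) for inhibition, read by sulforhodamine B assay, with a stated time of 48 h (on this read-out higher numbers stand for weaker inhibition of growth and lower numbers for stronger inhibition of growth), compound 2 gives 3900 nM, the only value in this set, so there is nothing to rank it against and no pair of measured compounds from which the size of any single change can be read.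

Compound 3 `C=C1CC[C@@H]2[C@](C)(COC(C)=O)[C@H](OC(C)=O)CC[C@@]2(C)[C@H]1CC(Nc1ccc(S(=O)(=O)Nc2cc(C)on2)cc1)C1=CCOC1=O` differs from compound 2 in one place: 5-methyl-1,2-oxazol-3-yl in place of 6-chloropyridazin-3-yl on a sulfonamide nitrogen. Within the data shown here, no measured step of this kind exists here, so the expectation rests on compound 2 alone, and a heteroaryl swap on the sulfonamide nitrogen is taken as unlikely to move the read-out far. The step expected from compound 2 to compound 3, a 1.2-fold higher number from compound 2 to compound 3 (0.06 log units; within the scatter), is none beyond the scatter, with the range widened in both directions for that uncertainty. Compound 3 is therefore estimated at 4500 nM, expected to fall between 1500 nM and 14000 nM.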

Compound 3, concentration for total growth inhibition: 4000 nM
Beside the measured number, compound 3's estimate is 1.1-fold (0.05 log units) above it; the range from low to high includes it.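

In this assay, this first readable step at the sulfonamide nitrogen is a 1.0-fold higher number from compound 2 to compound 3 (0.01 log units; within the scatter) and shows that the two compounds cannot be told apart on this read-out. The exchange is not a small one on paper: a six-membered aromatic ring carrying chlorine gives way to a five-membered aromatic ring carrying a methyl group and containing an oxygen, yet for this pair the growth-inhibition number stays within ordinary measurement scatter, so this position accepts either 6-chloropyridazin-3-yl or 5-methyl-1,2-oxazol-3-yl without a detectable penalty or gain. Why the two groups read alike cannot be said, as no supporting measurement bears on this result.

Any step involving compound 1 cannot be read, as it has no reported number, so two aromatic rings remain the entire basis for judging this position. The compounds shown leave open whether a group of a different kind on the same nitrogen, such as a plain phenyl ring, an acetyl group or a short alkyl chain, or simply a hydrogen there, would read the same or would shift the number beyond the scatter.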